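Methyl position swap on the anilino group of compound 1

The source may hold more compounds than are shown below. What is called first, only, known or untested is meant among the compounds shown, and "the series" means these compounds.

Measured compounds:
compound 1 `Cc1cccc(Nc2nc(SCc3cn(Cc4ccccc4Cl)nn3)nc(-c3ccccc3)c2C#N)c1`, 16200 nM
compound 2 `Cc1ccc(Cn2cc(CSc3nc(Nc4ccccc4Cl)c(C#N)c(-c4ccccc4)n3)nn2)cc1`, 17300 nM

In a functional assay on MGC-803 cells (Homo sapiens) for inhibition, read by MTT assay, with a stated time of 72 h (a higher number here means a weaker inhibitor, a lower number a stronger inhibitor), compound 1 gives 16200 nM. In this assay compound 2 gives 17300 nM. Compound 1 carries the lower of the two numbers, but the gap to compound 2 lies within the scatter, so the two cannot be ranked against each other.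

Compound 3 `Cc1ccc(Nc2nc(SCc3cn(Cc4ccccc4Cl)nn3)nc(-c3ccccc3)c2C#N)cc1` differs from compound 1 in a single place: 4-methylphenyl in place of 3-methylphenyl on a nitrogen on an aromatic ring. The change moves the methyl along the ring without adding or removing any atom, donor or acceptor. Among the measured compounds shown here, no measured pair shows such a change, so there is no basis in the numbers for expecting a shift beyond the scatter in either direction.

Compound 3 is therefore expected to come out close to compound 1, with an estimated step of a 1.1-fold lower number from compound 1 to compound 3 (0.03 log units; within the scatter). The estimate for compound 3 in this assay is 15000 nM, within a range from 7000 nM to 35000 nM.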

Compound 3, half-maximal inhibitory concentration: 7190 nM
Compound 3: the middle estimate sits 2.1-fold (0.32 log units) above what was measured, within the range that was stated.
By their numbers in this assay, from the lowest: compound 3; then compounds 1 and 2 (each within the scatter of the next).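

In this assay, among the compounds shown here, the change from 3-methylphenyl to 4-methylphenyl on a nitrogen on an aromatic ring gives a 2.3-fold lower number from compound 1 to compound 3 (0.35 log units; beyond the scatter) and is the first step that lies beyond the scatter. This position therefore responds to where the methyl stands on the ring, although the two groups have the same atom count and neither has a hydrogen-bond donor or acceptor. For the compounds shown here, nothing measured so far accounts for this modest step, which rests on a single pair.

Going by these compounds, whether a methoxy group or a chlorine in place of the methyl would follow the same trend remains open. Also open, on these data alone, is whether the same move of the methyl gives a similar step when other groups are present elsewhere on the core of compound 1.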